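Halogen exchange on the fused ring: compound 2 to compound 3

The source may hold more compounds than are shown below. What is called first, only, known or untested is meant among the compounds shown, and "the series" means these compounds.

Measured so far:
compound 1 `COc1ccc(C2CC(c3ccccc3)=NN2C2=NC(=O)/C(=C3\C(=O)Nc4ccccc43)S2)cc1` — 1640 nM
compound 2 `COc1ccc(-c2cc(-c3ccc(Cl)cc3)n(C3C(=O)Nc4ccc(Br)cc43)n2)cc1` — 12400 nM

In a functional assay on cells (Leukemia cell, Homo sapiens) for cytotoxicity, read by sulforhodamine B assay, with a stated time of 48 h (on this read-out higher numbers stand for weaker inhibition of growth and lower numbers for stronger inhibition of growth), compound 1 gives 1640 nM and compound 2 gives 12400 nM. Compound 2 thus holds the highest of the two numbers, and its gap to compound 1 lies beyond the scatter of repeat measurements. Among the measured compounds shown here, the two compounds differ in more than one place, so no single measured step is available.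

Compound 3 `COc1ccc(-c2cc(-c3ccc(Cl)cc3)n(C3C(=O)Nc4ccc(Cl)cc43)n2)cc1` differs from compound 2 in one place: chloro in place of bromo on an aromatic carbon. For the measured compounds named here, no step of this kind has been measured here. An exchange of one halogen for another, with no change in ring count, donors, acceptors or charge, is expected to move the read-out little; the step of a 1.0-fold lower number from compound 2 to compound 3 (0.01 log units; within the scatter) is expected to stay within the usual scatter, in no settled direction. Compound 3 is accordingly estimated at 12000 nM, with a range from 5000 nM to 30000 nM.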

Compound 3, concentration for 50% growth inhibition: 28000 nM
Compound 3: the middle estimate sits 2.3-fold (0.37 log units) below what was measured, and the stated range covers the measured number.
By their numbers in this assay, from the lowest: compound 1; then compound 2; then compound 3.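

In this assay, the series gains its first single-place step: chloro in place of bromo on an aromatic carbon of the fused system gives a 2.3-fold higher number from compound 2 to compound 3 (0.35 log units; beyond the scatter) and so registers as a modest change. This position therefore responds to an exchange of one halogen for another, even with no change in rings, hydrogen-bond donors, hydrogen-bond acceptors or net charge, and bromo gives the stronger inhibition of growth of this pair. Nothing measured here accounts for the difference between the two halogens. 

The compounds shown leave open how fluoro, iodo, an amine or a methoxy group at this carbon would read, and whether any would give a lower number than bromo. Compound 1 differs from both compounds in more than one place, so it offers no reading on this position.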